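Replacing the aromatic group on the double-bonded chain

The source may report more compounds than this note shows. Statements on the series, on what has been measured and on what is new or still open speak of the compounds shown alone.

Of the compounds shown here, three sharing one core have been measured. Going by the values given here, in a functional assay on A549 cells (Homo sapiens) for antiproliferative activity, read by MTT assay, with a stated time of 48 h (on this read-out lower numbers stand for stronger inhibition and higher numbers for weaker inhibition), compound 1 `Clc1cccc(Nc2ncnc3ccc(NCc4cccs4)cc23)c1` gives 2080 nM, and compound 2 `Cc1cccc(CNc2ccc3ncnc(Nc4cccc(Cl)c4)c3c2)n1` gives 1060 nM; the single one-place step among them, a 2.0-fold lower number from compound 1 to compound 2 (0.29 log units; within the scatter), exchanges one aromatic group for another. Compound 3 `O=C(/C=C/c1ncc2ccccc2n1)Nc1ccc2ncnc(Nc3cccc(Cl)c3)c2c1` gives 3350 nM, the highest of the three numbers, though its gap to compound 1 lies within the scatter and only its gap to compound 2 beyond it. Compound 4 `O=C(/C=C/c1cccnc1Cl)Nc1ccc2ncnc(Nc3cccc(Cl)c3)c2c1` differs from compound 3 by 2-chloropyridin-3-yl in place of quinazolin-2-yl on a double-bonded chain carbon bound to a double-bonded chain carbon. Among the compounds with values here, the one measured step, also an exchange of aromatic groups that stayed within the scatter, is the nearest comparison, so no change beyond the scatter is expected here, a 1.1-fold lower number from compound 3 to compound 4 (0.05 log units; within the scatter). Compound 4 is therefore estimated at 3000 nM, within a range from 1000 nM to 9000 nM.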

Compound 4, half-maximal inhibitory concentration: 2920 nM
Beside the measured number, compound 4's estimate is 1.0-fold (0.01 log units) above it; the range from low to high includes it.
By their numbers in this assay, from the lowest: compounds 2, 1, 4 and 3 (each within the scatter of the next, the first and the last beyond it).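

On a double-bonded chain carbon bound to a double-bonded chain carbon, 2-chloropyridin-3-yl replaces quinazolin-2-yl with a 1.1-fold lower number from compound 3 to compound 4 (0.06 log units; within the scatter) in this assay. At this position, then, an exchange that removes a ring of carbon only and brings in a chlorine leaves the number within the scatter. No measurement here bears on this result. Still open is whether the chlorine matters, since plain pyridin-3-yl does not appear among these compounds. Also open, on these data alone, is how a non-aromatic group, such as an amine or a carboxylic acid, would behave on this carbon.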